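A Fluoro to Nitro Change at Compound 2

The source may report more compounds than this note shows. Statements on the series, on what has been measured and on what is new or still open speak of the compounds shown alone.

- Compound 1 `CCOC(=O)N1CCC(=NNC(=O)c2ccc(Cl)cc2)CC1`: 59000 nM
- Compound 2 `O=C(NN=C1CC(c2ccccc2)NC(c2ccccc2)C1)c1ccc(F)cc1`: 66000 nM

In a functional assay, read by spectrophotometry, with a stated time of 2 h (on this read-out lower numbers stand for stronger inhibition and higher numbers for weaker inhibition), compound 2 gives 66000 nM, which lies within the scatter of compound 1 at 59000 nM. Compound 3 `O=C(NN=C1CC(c2ccccc2)NC(c2ccccc2)C1)c1ccc([N+](=O)[O-])cc1` has not yet been measured. It differs from compound 2 by one change, nitro in place of fluoro on an aromatic carbon, para to a large group. Within the data shown here, no measured pair shows a comparable single change, so no shift beyond the scatter is expected in this assay. The expected change is a 1.2-fold lower number from compound 2 to compound 3 (0.08 log units; within the scatter). Compound 3 is estimated at 55000 nM, with an expected range of 18000 nM to 160000 nM.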

Compound 3, half-maximal inhibitory concentration: 88100 nM
Beside the measured number, compound 3's estimate is 1.6-fold (0.20 log units) below it; the range from low to high includes it.
By their numbers in this assay, from the lowest: compounds 1, 2 and 3 (each within the scatter of the next).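

In this assay, among these compounds, 4-nitrophenyl in place of 4-fluorophenyl gives a 1.3-fold higher number from compound 2 to compound 3 (0.13 log units; within the scatter) and so offers the first reading of a single change at this position, on an aromatic carbon para to a large group. Here nitro, with its 3 heavy atoms, cannot be told apart from fluoro, with its 1 heavy atom. Nothing measured at hand bears on this result.

From the compounds shown here alone, whether an amine or a carboxylic acid at this position would shift the number beyond the scatter stays open, in either direction.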